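The source may hold more compounds than are shown below. What is called first, only, known or untested is meant among the compounds shown, and "the series" means these compounds.

Compound 1, `Cc1c(OCc2cccnc2)ccc2c(N3CCNCC3)cc(=O)oc12`: 980 nM in a functional assay on a cell-free system (plasma, Homo sapiens) for inhibition, with Plasma (Rattus norvegicus) as the target; a higher number here means a weaker inhibitor, a lower number a stronger inhibitor
Compound 2, `CCCOc1ccc2c(N3CCNCC3)cc(=O)oc2c1C`: 2950 nM
Compound 3, `CSCCOc1ccc2c(N3CCNCC3)cc(=O)oc2c1C`: 1500 nM

Among these three numbers compound 1 gives the lowest; compound 3 comes nearest to it, the step of a 1.5-fold higher number from compound 1 to compound 3 (0.18 log units; within the scatter) lying within the scatter, while compound 2 sits furthest away, the step of a 3.0-fold higher number from compound 1 to compound 2 (0.48 log units; beyond the scatter) lying beyond it. Compound 4, `Cc1c(OCCOc2ccccc2)ccc2c(N3CCNCC3)cc(=O)oc12`, has not yet been measured in this assay. It differs from compound 1 in one place: phenoxymethyl in place of pyridin-3-yl on a saturated chain carbon bound to an oxygen on an aromatic ring. Among the measured compounds shown here, two measured steps bear on this change. Both of them also replace the pyridin-3-yl group on the saturated chain carbon bound to an oxygen on an aromatic ring: the step of a 3.0-fold higher number from compound 1 to compound 2 (0.48 log units; beyond the scatter) was modest and beyond the scatter, and the step of a 1.5-fold higher number from compound 1 to compound 3 (0.18 log units; within the scatter) stayed within it. Both point the same way, so a number that is somewhat higher than that of compound 1, though at most modestly so, is expected for compound 4. The estimate for compound 4 is 1600 nM, with a range from 600 nM to 4500 nM, which amounts to an expected step of a 1.6-fold higher number from compound 1 to compound 4 (0.21 log units; within the scatter).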

Compound 4, half-maximal inhibitory concentration: 9400 nM
For compound 4 the middle estimate is 5.9-fold (0.77 log units) below the measured one, outside the stated range (above it).
By their numbers in this assay, from the lowest: compounds 1, 3 and 2 (each within the scatter of the next, the first and the last beyond it); then compound 4.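

In this assay the 2-phenoxyethyl group does not stay close to the earlier groups at this place: the change from (pyridin-3-yl)methyl gives a 9.6-fold higher number from compound 1 to compound 4 (0.98 log units; beyond the scatter), and the rise persists against the two smaller chains, with a 6.3-fold higher number from compound 3 to compound 4 (0.80 log units; beyond the scatter) and a 3.2-fold higher number from compound 2 to compound 4 (0.50 log units; beyond the scatter). An aromatic ring on the chain therefore does not by itself keep the number low, as compound 1 and compound 4 each carry one, yet their numbers lie furthest apart of the four. Nothing available here gives a reason for this rise.

As far as these compounds go, it remains open whether a 3-phenylpropyl group, with carbon where the phenoxy oxygen stands, or a plain benzyl group would come closer to compound 1 or to compound 4. Also open, from the compounds shown here alone, is how a 2-(pyridin-3-yloxy)ethyl group, which puts the ring nitrogen back into the longer chain, would compare with compound 4.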